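Benzyl to sec-Butyl: Expecting the Next Measurement

The source may report more compounds than this note shows. Statements on the series, on what has been measured and on what is new or still open speak of the compounds shown alone.

Three compounds have been measured in a functional assay on NCI-H460 cells (Homo sapiens) for antiproliferative activity, read by CCK-8 assay, with a stated time of 72 h, tested at 2 uM; a higher number here means a stronger effect of the compound at the concentration tested, a lower number a weaker effect:

Compound 1 `CN1CCN(c2nc(Cl)nc3c2ncn3Cc2ccc(C(=O)Nc3ccccc3N)cc2)CC1` gives 13.5%
Compound 2 `Nc1ccccc1NC(=O)/C=C/c1ccc(Cn2cnc3c(Nc4cccc(Cl)c4)nc(Cl)nc32)cc1` gives 7.11%
Compound 3 `Nc1ccccc1NC(=O)c1ccc(CNc2nc(Cl)nc3c2ncn3Cc2ccccc2)cc1` gives 43.8%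

Compound 3 stands highest of the three numbers; compound 1 lies lower by a gap beyond the usual scatter, and compound 2 lies lower still, also beyond the scatter. Compound 4 `CCC(C)n1cnc2c(NCc3ccc(C(=O)Nc4ccccc4N)cc3)nc(Cl)nc21` has not yet been measured. It differs from compound 3 in one place: sec-butyl in place of benzyl on an aromatic nitrogen. Among the compounds with values here, no pair of measured compounds shows a change of this kind, so its size cannot be read from the numbers. The step of a number 13.8 percentage points lower from compound 3 to compound 4 (beyond the scatter) is expected to be a moderate decrease, possibly no more than the scatter. Compound 4 is therefore estimated at 30%, within a range from 10% to 55%.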

Compound 4, a percentage reported as inhibition, at one concentration (the size of the read-out at that concentration, not a potency): 47.3%
Estimate against measurement, compound 4: 17.3 percentage points below; measured number inside the range.
By their numbers in this assay, from the lowest: compounds 2 and 1 (each within the scatter of the next); then compounds 3 and 4 (each within the scatter of the next).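

In this assay, putting sec-butyl in place of benzyl on the aromatic nitrogen gives a number 3.5 percentage points higher from compound 3 to compound 4 (within the scatter), so the two compounds cannot be told apart. At this position, then, the read-out at this single concentration does not depend on keeping the six-membered aromatic ring, and a smaller group without a ring serves as well. Nothing shown here explains why the two groups read alike.

As far as these compounds go, whether this tolerance extends to a longer chain, or to a group of a different kind such as an amine or a carboxylic acid, remains open. A single concentration also leaves the potency of both compounds unknown.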